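The source may report more compounds than this note shows. Statements on the series, on what has been measured and on what is new or still open speak of the compounds shown alone.

Working notes on the hydroxamic acid series built on the shared core of compound 3 `O=C(CCC1=CCCN(Cc2ccc([N+](=O)[O-])cc2)C1=O)NO`; the substituent on the benzyl ring is the point of variation. In a functional assay on MDA-MB-231 cells (Homo sapiens) for inhibition, read by sulforhodamine B assay (on this read-out lower numbers stand for stronger inhibition of growth and higher numbers for weaker inhibition of growth), compound 3 gives 470 nM, the lowest of the two numbers obtained so far. Compound 2 `Cc1cccc(CN2CCC=C(CCC(=O)NO)C2=O)c1`, carrying a methyl group instead, gives in this assay 8120 nM, a number that lies beyond the scatter above compound 3; since the two compounds differ in more than one place, only what their two values show can be read from them. Compound 1 `CC(=O)Nc1ccc(CN2CCC=C(CCC(=O)NO)C2=O)cc1` has in this assay "not determined" (no result reported), so no number is available for it.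

Compound 4 `O=C(CCC1=CCCN(Cc2ccc(Br)cc2)C1=O)NO` is still to be measured. It differs from compound 3 by bromo in place of nitro on an aromatic carbon. Within the data shown here, no pair of measured compounds isolates this change, so there is nothing in hand to calibrate it. Given that compound 3 with 470 nM is the only close anchor, the expected step is small and toward weaker inhibition, probably not beyond the scatter; the estimated change from compound 3 to compound 4 is a 1.9-fold higher number from compound 3 to compound 4 (0.28 log units; within the scatter). Compound 4 is estimated to give 900 nM in this assay, within a range from 300 nM to 3000 nM.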

Compound 4, concentration for 50% growth inhibition: 1630 nM
Estimate against measurement, compound 4: 1.8-fold (0.26 log units) below, and the stated range covers the measured number.
By their numbers in this assay, from the lowest: compound 3; then compound 4; then compound 2.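

Among these compounds, this is the first step measured at this place, on an aromatic carbon para to a large group. In this assay, bromo in place of nitro gives a step beyond the scatter (a 3.5-fold higher number from compound 3 to compound 4 (0.54 log units; beyond the scatter)), so a single exchange of substituent here is enough to shift the growth-inhibition number. Changing the ring substituent the other way, 4-bromophenyl in place of 3-methylphenyl gives a step also beyond the scatter (a 5.0-fold lower number from compound 2 to compound 4 (0.70 log units; beyond the scatter)), which places compound 4 between compound 3 and compound 2, although this step changes both the group and its place on the ring and so does not separate the two. Nothing available on these compounds accounts for either step.

Among the compounds shown here, still open is whether a chloro, methoxy or amino group at the same place would fall nearer compound 3 or compound 4, since nitro and bromo are the only two groups compared there with nothing else changed. Also open, from the compounds shown here alone, is how much of the step from compound 2 belongs to the methyl group itself and how much to where it sits, which a 4-methylphenyl analogue would separate.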